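Swapping methoxy for nitro on the styryl ring

This account rests on a few compounds, and the source may have more. Where it says the series, first, only, none or still open, it means among the compounds named here.

The three measured compounds share one core, differing only in a single substituent on the six-membered aromatic ring of carbon only. In an ADME assay on cells (Macrophage, Homo sapiens) for cytotoxicity, read by MTT assay, with a stated time of 24 h (a higher number here means that more compound is tolerated, a lower number that less compound is tolerated), compound 1 `CC(O)Cn1c([N+](=O)[O-])cnc1/C=C/c1ccccc1` gives 1500 nM, compound 2 `CC(O)Cn1c([N+](=O)[O-])cnc1/C=C/c1cccc(Cl)c1` gives 520 nM, and compound 3 `COc1cccc(/C=C/c2ncc([N+](=O)[O-])n2CC(C)O)c1` gives 1300 nM, which is the second highest of the three numbers; its step to compound 1 lies within the scatter, while a 2.5-fold higher number from compound 2 to compound 3 (0.40 log units; beyond the scatter) is beyond it. Compound 4 `CC(O)Cn1c([N+](=O)[O-])cnc1/C=C/c1cccc([N+](=O)[O-])c1` carries the change (nitro in place of methoxy on an aromatic carbon). Going by the values given here, no measured step involves nitro, so the bearing steps are those at the same place: a 1.2-fold lower number from compound 1 to compound 3 (0.06 log units; within the scatter) was within the scatter, whereas a 2.9-fold lower number from compound 1 to compound 2 (0.46 log units; beyond the scatter) and a 2.5-fold higher number from compound 2 to compound 3 (0.40 log units; beyond the scatter) were modest but beyond it, showing that a substituent other than methoxy at this place has lowered the tolerated concentration once. A modest step downward in this assay is therefore expected for compound 4, with a 1.6-fold lower number from compound 3 to compound 4 (0.21 log units; within the scatter), and compound 4 is estimated at 800 nM, within a range from 350 nM to 1900 nM.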

Compound 4, half-maximal cytotoxic concentration: 430 nM
Estimate against measurement, compound 4: 1.9-fold (0.27 log units) above; low and high end bracket the measured number.
By their numbers in this assay, from the lowest: compounds 4 and 2 (each within the scatter of the next); then compounds 3 and 1 (each within the scatter of the next).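

In this assay, nitro on this aromatic carbon gives a clear drop against methoxy, with a 3.0-fold lower number from compound 3 to compound 4 (0.48 log units; beyond the scatter), and against the unsubstituted ring, with a 3.5-fold lower number from compound 1 to compound 4 (0.54 log units; beyond the scatter). Against chloro there is no real separation, with a 1.2-fold lower number from compound 2 to compound 4 (0.08 log units; within the scatter), so nitro and chloro cannot be told apart here. Going by these compounds alone, until now, chloro was the only group at this place to lower the tolerated concentration; a second group now does so, and the four compounds fall into two groups, compounds 2 and 4 at the low end and compounds 1 and 3 at the high end.

Nothing available explains this split. As far as these compounds go, it also remains open whether an amine or a carboxylic acid at this place would join the nitro and chloro compounds or the methoxy and hydrogen compounds.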